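A few compounds are considered here, and "the series" means these few. Any claim that something is new, unique, unknown or untested is made for them only; others in the source may bear on it.

Measured so far: compound 1 `CC1=CC[C@H](C(C)(C)NC(=S)N/N=C/c2ccccc2[N+](=O)[O-])CC1`, 70800 nM; compound 2 `CC1=CC[C@H](C(C)(C)NC(=S)N/N=C(\C)c2ccccc2)CC1`, > 100000 nM; compound 3 `COc1ccc(/C(C)=N/NC(=S)NC(C)(C)[C@H]2CC=C(C)CC2)cc1`, > 100000 nM.

The three compounds share one core and differ only in the aromatic part. In a functional assay on HT-29 cells (Homo sapiens) for inhibition, read by sulforhodamine B assay, with a stated time of 48 h (a lower number here means a stronger inhibitor of growth, a higher number a weaker inhibitor of growth), compound 1 gives 70800 nM, a number. Compound 2 reaches only the assay limit, > 100000 nM. Compound 3 likewise sits at the limit, > 100000 nM. Compound 3 thus stands among the weakest growth inhibitors the assay can report, and it shares that place with compound 2, as the limit of > 100000 nM in this assay, at which 2 of the 3 values shown sit, shows. The step that the two limits leave unreadable from compound 2 to compound 3 therefore cannot be read.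

Compound 4 `CC1=CC[C@H](C(C)(C)NC(=S)N/N=C(\C)c2ccc([N+](=O)[O-])cc2)CC1` comes from compound 3 by nitro in place of methoxy on an aromatic carbon. Going by the values given here, only one measured step touches this position, the one from compound 2 to compound 3, and its size is hidden behind the limit. Compound 1 carries a nitro group as well and returns a number rather than a limit, 70800 nM. On that slender basis compound 4 is expected close to the limit, with the step of an at least 1.1-fold lower number from compound 3 to compound 4 (0.04 log units; that floor lies within the scatter) not expected to be readable beyond the scatter. Compound 4 is estimated at 90000 nM, between 30000 nM and 300000 nM.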

Compound 4, concentration for total growth inhibition: > 100000 nM
Compound 4 gave a limit, no number; the forecaster's own chance of this, stated with the estimate: 55%; middle value at least 1.1-fold (0.04 log units) away from the limit.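

In this assay compound 4 gives > 100000 nM, which is a limit and not a number. Its steps from compound 2 and from compound 3 cannot be read, because these three compounds all sit at the same limit: the limit of > 100000 nM in this assay, at which 3 of the 4 values shown sit.

The compounds shown leave open whether hydrogen, methoxy and nitro on that aromatic carbon differ at all in this assay.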